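A few compounds are considered here, and "the series" means these few. Any claim that something is new, unique, unknown or untested is made for them only; others in the source may bear on it.

Working notes on the series.

In an assay on HEK293 cells for inhibition of Voltage-dependent T-type calcium channel subunit alpha-1G (Homo sapiens), read by fluorescence, tested at 10 uM (on this read-out higher numbers stand for more inhibition at the one concentration tested (going by the name of the read-out) and lower numbers for less inhibition), the three measured compounds span a modest band. Compound 1 `CCCc1nc(-c2ccccc2)c(CNCCN2CCN(c3cccc(C)c3C)CC2)o1` gives 66.7%. Compound 2 `CCCc1nc(-c2ccccc2)c(CNCCN2CCN(c3cccc(OC)c3)CC2)o1` gives 40.2%. Compound 3 `CCCc1nc(-c2ccccc2)c(CNCCN2CCN(c3cccc(Cl)c3)CC2)o1` gives 51.2%, which is the second highest of the three numbers: it lies a number 15.5 percentage points lower from compound 1 to compound 3 (beyond the scatter) and a number 11 percentage points higher from compound 2 to compound 3 (beyond the scatter).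

Compound 4 `CCCc1nc(-c2ccccc2)c(CNCCN2CCN(c3ccc(C(F)(F)F)cc3)CC2)o1` is not yet measured. Its change from compound 3 is 4-(trifluoromethyl)phenyl in place of 3-chlorophenyl on an amine nitrogen in a ring. Among the compounds with values here, no measured step swaps in this group, so the only guide is how much the number has moved when the aryl group on the ring nitrogen was exchanged: a number 26.5 percentage points lower from compound 1 to compound 2 (beyond the scatter), a number 15.5 percentage points lower from compound 1 to compound 3 (beyond the scatter), a number 11 percentage points higher from compound 2 to compound 3 (beyond the scatter). Each such exchange moved the read-out beyond the scatter, in both directions, by roughly the same amount. The expected step in this assay is therefore small and of uncertain direction, estimated as a number 1.2 percentage points lower from compound 3 to compound 4 (within the scatter). Compound 4 is expected to give about 50%, within a range from 30% to 70%.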

Compound 4, a percentage reported as inhibition, at one concentration (the size of the read-out at that concentration, not a potency): 58.7%
Beside the measured number, compound 4's estimate is 8.7 percentage points below it, and the stated range covers the measured number.
By their numbers in this assay, from the lowest: compound 2; then compounds 3, 4 and 1 (each within the scatter of the next, the first and the last beyond it).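

In this assay, within the data shown here, the 4-(trifluoromethyl)phenyl group on the amine nitrogen in a ring gives the first exchanges at this position that stay within the scatter: a number 7.5 percentage points higher from compound 3 to compound 4 (within the scatter) and a number 8 percentage points lower from compound 1 to compound 4 (within the scatter). Among these compounds, each exchange among the earlier compounds had moved the read-out beyond the scatter, so a change of aryl group here does not always separate two compounds. Only the comparison with the 3-methoxyphenyl group separates, at a number 18.5 percentage points higher from compound 2 to compound 4 (beyond the scatter), which leaves compound 2 beyond the scatter of all three other compounds. No supporting data bear on why these numbers fall as they do.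

The compounds shown do not separate the identity of the substituent from its place on the phenyl ring. Also open, on these data alone, is how an unsubstituted phenyl, a pyridine or a cyclohexyl group on that nitrogen would read.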